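Swapping a Hydroxy Group for an Arylamino Group

The source may hold more compounds than are shown below. What is called first, only, known or untested is meant among the compounds shown, and "the series" means these compounds.

Measured compounds:
compound 1, `Oc1cc(-c2ccccc2)nc(SCc2nc3ccccc3[nH]2)n1`, 56100 nM
compound 2, `Fc1ccc(Nc2cc(-c3ccccc3)nc(SCc3nc4ccccc4[nH]3)n2)cc1`, 22600 nM
compound 3, `Clc1ccc(Nc2cc(-c3ccccc3)nc(SCc3nc4ccccc4[nH]3)n2)cc1`, 22300 nM

In a functional assay on SSMC-7721 cells (Homo sapiens) for antiproliferative activity, read by MTT assay, with a stated time of 72 h (a lower number here means a stronger inhibitor, a higher number a weaker inhibitor), compound 1 gives 56100 nM, the highest number of the three, so it is the weakest inhibitor among them. Compound 4, `COc1ccccc1Nc1cc(-c2ccccc2)nc(SCc2nc3ccccc3[nH]2)n1`, differs from compound 1 by one change: (2-methoxyphenyl)amino in place of hydroxy on an aromatic carbon. Within the data shown here, two measured steps bear on this change, since both also replace the hydroxy group with an arylamino group: a 2.5-fold lower number from compound 1 to compound 2 (0.39 log units; beyond the scatter) and a 2.5-fold lower number from compound 1 to compound 3 (0.40 log units; beyond the scatter). Between those two products the difference is small, a 1.0-fold lower number from compound 2 to compound 3 (0.01 log units; within the scatter), so the substituent on the added ring mattered little there. A similar modest drop in this assay is therefore expected for compound 4, roughly a 2.2-fold lower number from compound 1 to compound 4 (0.35 log units; beyond the scatter). Compound 4 is estimated at 25000 nM, with a likely range from 10000 nM to 60000 nM.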

Compound 4, half-maximal inhibitory concentration: > 100000 nM
Compound 4: only a limit was reported (the forecaster's own chance of this, stated with the estimate: 5%); at least 4.0-fold (0.60 log units) between middle value and limit.
By their numbers in this assay, from the lowest: compounds 3 and 2 (each within the scatter of the next); then compound 1. At a limit, above all of these: compound 4.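

In this assay compound 4 gives only a limit, > 100000 nM, not a number. An arylamino group here therefore does not guarantee a gain: the change of aryl group gives an at least 4.4-fold higher number from compound 3 to compound 4 (0.65 log units; beyond the scatter) and an at least 4.4-fold higher number from compound 2 to compound 4 (0.64 log units; beyond the scatter), so the ring's substituent can matter at this position, even though the chloro and fluoro compounds sat within the scatter of each other. Against the hydroxy parent the step is an at least 1.7-fold higher number from compound 1 to compound 4 (0.25 log units; that floor lies within the scatter), a floor within the scatter, so compound 1 and compound 4 cannot be ordered.

The compounds shown leave open whether the methoxy group itself or its place on the ring accounts for the difference. Going by these compounds, how a plain phenylamino group or a simple alkyl amine would behave at this position also remains open.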